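A few compounds are considered here, and "the series" means these few. Any claim that something is new, unique, unknown or untested is made for them only; others in the source may bear on it.

In a functional assay on 3T3-L1 cells (Mus musculus) for inhibition, with a stated time of 20 min, tested at 20 uM (a higher number here means more inhibition at the concentration tested (going by the name of the read-out), a lower number less inhibition), two compounds have been tested. Compound 1 `Cc1ccc(S(=O)(=O)N(Cc2cn(Cc3ccccc3Cl)nn2)Cc2cn(S(=O)(=O)c3ccc(C)cc3)c3ccccc23)cc1` gives -4.8%, the higher of the two numbers, a value that amounts to essentially no inhibition. Compound 2 `O=C(N(Cc1ccc(F)cc1)Cc1cccc(F)c1F)C(F)(F)F` gives -39.8%, a gap from compound 1 that lies beyond the scatter. Compound 3 `COc1cc(OC)c(Cn2cc(CN(Cc3cn(S(=O)(=O)c4ccc(C)cc4)c4ccccc34)S(=O)(=O)c3ccc(C)cc3)nn2)c(OC)c1` awaits measurement and differs from compound 1 in one place: 2,4,6-trimethoxyphenyl in place of 2-chlorophenyl on a saturated chain carbon bound to an aromatic nitrogen. Among the measured compounds shown here, no measured pair shows what such a change does, so no shift beyond the scatter is expected, because compound 1 already sits near zero at -4.8%. Compound 3 is therefore estimated at -3%, between -28% and 22%. The expected step is a number 1.8 percentage points higher from compound 1 to compound 3 (within the scatter).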

Compound 3, a percentage reported as inhibition, at one concentration (the size of the read-out at that concentration, not a potency): -22%
Estimate against measurement, compound 3: 19 percentage points above; measured number inside the range.
By their numbers in this assay, from the lowest: compound 2; then compound 3; then compound 1.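

In this assay, exchanging the 2-chlorophenyl for 2,4,6-trimethoxyphenyl gives a number 17.2 percentage points lower from compound 1 to compound 3 (beyond the scatter). This position is therefore not indifferent to the group it carries, and this change moves the read-out towards less inhibition. Nothing available explains the shift.

The pair cannot separate the loss of the chlorine from the arrival of the three methoxy groups. On these data alone, an unsubstituted phenyl or a pyridine ring at this position could help to separate them, and whether any group here gives a clearly positive inhibition remains open.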